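The compounds below may be only part of what the source reports. "The series", "measured", "known", "first", "only" and "open" are said of these compounds alone.

Measured compounds:
- compound 1, `CC1=C(/C=C/C(=O)/C=C/c2ccccc2Cl)C(C)(C)CCC1` — 21800 nM
- compound 2, `CC1=C(/C=C/C(=O)/C=C/c2ccccc2Br)C(C)(C)CCC1` — 57900 nM

Among the compounds with values here, in a functional assay on HeLa cells (Homo sapiens) for cytotoxicity, read by sulforhodamine B assay, with a stated time of 48 h (a lower number here means a stronger inhibitor, a higher number a weaker inhibitor), compound 2 gives 57900 nM, the higher of the two numbers measured so far; compound 1 gives 21800 nM, and the step of a 2.7-fold higher number from compound 1 to compound 2 (0.42 log units; beyond the scatter) separates them clearly.

Compound 3, `CC1=C(/C=C/C(=O)/C=C/c2ccccc2F)C(C)(C)CCC1`, differs from compound 2 in one place: fluoro in place of bromo on an aromatic carbon. It is thus a third member of the same halogen series, with the smallest of the three halogens on the same position of the ring.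

Within the data shown here, only one measured step bears on this change, a 2.7-fold higher number from compound 1 to compound 2 (0.42 log units; beyond the scatter), in which the heavier halogen brought a modest rise in the number. Replacing bromo by fluoro moves in the opposite direction along that series, and by a larger distance than the chloro-to-bromo step. Among the measured compounds shown here, no fluoro compound has been measured here, so the expectation rests on that single step alone. A modest decrease is therefore expected, a 2.3-fold lower number from compound 2 to compound 3 (0.36 log units; beyond the scatter), with the direction less certain than its size.

For compound 3 the expected value in this assay is 25000 nM, within a range of 8000 nM to 80000 nM.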

Compound 3, half-maximal inhibitory concentration: 41900 nM
Estimate against measurement, compound 3: 1.7-fold (0.22 log units) below; the range from low to high includes it.
By their numbers in this assay, from the lowest: compounds 1, 3 and 2 (each within the scatter of the next, the first and the last beyond it).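

In this assay the fluoro of compound 3 cannot be told apart from the bromo, with a 1.4-fold lower number from compound 2 to compound 3 (0.14 log units; within the scatter), or from the chloro, with a 1.9-fold higher number from compound 1 to compound 3 (0.28 log units; within the scatter). The earlier pair alone suggested that this place on the ring responds clearly to the choice of halogen, with a 2.7-fold higher number from compound 1 to compound 2 (0.42 log units; beyond the scatter), but the third member shows that this is the only gap in the series that lies beyond the scatter, and no steady line can be drawn from fluoro through chloro to bromo, since compound 3 lies within the scatter of both other compounds. Nothing shown here accounts for these numbers.

The compounds shown leave open whether a group other than a halogen at this place, such as an amine, a methoxy group or a nitrile, would move the number well outside the narrow band that these three halogens occupy. They also leave open whether the same halogens would behave alike elsewhere on the ring, and whether changes to the shared core would matter more than any change made here.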